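Replacing the nitrile of compound 1 with an oxazole

The source may report more compounds than this note shows. Statements on the series, on what has been measured and on what is new or still open speak of the compounds shown alone.

Measured so far in an assay on cells for binding affinity to Myc proto-oncogene protein (Homo sapiens); on this read-out lower numbers stand for stronger inhibition and higher numbers for weaker inhibition:
- compound 1 `N#Cc1ccc(-c2cc(-c3ccc(C(N)=O)cc3)cc(-c3ccco3)n2)cc1`: 3000 nM
- compound 2 `N#Cc1ccc(-c2cc(-c3ccc(C(N)=O)cc3)cc(-c3cncs3)n2)cc1`: 30000 nM
- compound 3 `N#Cc1ccc(-c2cc(-c3ccc(C(N)=O)cc3)cc(-c3cnco3)n2)cc1`: for compound 3 the assay gives only a limit, > 100000 nM

Compound 1 gives the lowest of the two numbers in this assay; the nearest is compound 2 at a 10-fold higher number from compound 1 to compound 2 (1.00 log units; beyond the scatter). Compound 3 sits at the limit, (the limit of > 100000 nM in this assay, at which 1 of the 3 values shown sits). The measured steps all concern the five-membered heteroaryl on the shared core: an at least 33-fold higher number from compound 1 to compound 3 (1.52 log units; beyond the scatter) and an at least 3.3-fold higher number from compound 2 to compound 3 (0.52 log units; beyond the scatter).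

Compound 4 `NC(=O)c1ccc(-c2cc(-c3ccc(-c4cnco4)cc3)nc(-c3ccco3)c2)cc1` changes a different place. Relative to compound 1 the change is 1,3-oxazol-5-yl in place of cyano on an aromatic carbon. Within the data shown here, no measured step touches this position, so none of the steps bears directly on it; the only related observation is that an oxazole at the other position, from compound 1 to compound 3, went with a large loss. That is taken as weak guidance only. The step is therefore expected to be a modest rise, a 3.3-fold higher number from compound 1 to compound 4 (0.52 log units; beyond the scatter), with wide uncertainty. Compound 4 is estimated at 10000 nM, between 2000 nM and 60000 nM.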

Compound 4, half-maximal inhibitory concentration: 2500 nM
Compound 4: middle estimate off by 4.0-fold (0.60 log units), on the high side, and the stated range covers the measured number.
By their numbers in this assay, from the lowest: compounds 4 and 1 (each within the scatter of the next); then compound 2. At a limit, above all of these: compound 3.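

In this assay, the place para to a large group accepts a five-membered aromatic ring with 2 hetero atoms in place of the nitrile: a 1.2-fold lower number from compound 1 to compound 4 (0.08 log units; within the scatter), so at this position the nitrile can be exchanged for 1,3-oxazol-5-yl with no change beyond the scatter. The same 1,3-oxazol-5-yl in place of furan-2-yl gives an at least 33-fold higher number from compound 1 to compound 3 (1.52 log units; beyond the scatter), a step that rests on a limit for compound 3, so in this pair of changes the outcome depends on where the group sits on the shared core. Nothing measured here gives a reason for this difference between the two positions.

Going by these compounds, it remains open whether this position also accepts a group with no ring, such as an amine or a carboxylic acid. One replacement also cannot show whether 1,3-thiazol-5-yl or a phenyl ring would behave like 1,3-oxazol-5-yl here.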